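This account rests on a few compounds, and the source may have more. Where it says the series, first, only, none or still open, it means among the compounds named here.

Measured compounds:
compound 1, `CS(=O)(=O)CCCn1c(Cn2cc(S(C)(=O)=O)c3ccncc32)nc2cc(Cl)ccc21`: in an ADME assay on HEp-2 cells (Homo sapiens) for cytotoxicity, with a stated time of 4 days (on this read-out higher numbers stand for lower toxicity in this test and lower numbers for higher toxicity in this test), compound 1 gives > 100000 nM, a limit of the assay.
compound 2, `CCS(=O)(=O)c1cn(Cc2nc3cc(Cl)ccc3n2CCCS(C)(=O)=O)c2ccccc12`: in this assay compound 2 gives > 100000 nM, a limit of the assay.
compound 3, `CS(=O)(=O)c1nn(Cc2nc3cc(Cl)ccc3n2CCCO)c2cnccc12`: in this assay compound 3 gives > 100000 nM, a limit of the assay.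

Compound 3 therefore stands where every value shown stands: at the limit of > 100000 nM in this assay, at which 3 of the 3 values shown sit, with no number distinguishing it from compound 1 or compound 2. The unmeasured compound 4, `CS(=O)(=O)c1nn(Cc2nc3cc(Cl)ccc3n2CCCCC(F)(F)F)c2cnccc12`, differs from compound 3 by 2,2,2-trifluoroethyl in place of hydroxy on a saturated chain carbon, three bonds along the chain from an aromatic nitrogen. Among the measured compounds shown here, no step between measured compounds is available, so the expectation rests on the three limits alone; the author expects no change beyond the usual scatter in this assay, with compound 4 most likely again reported as a limit. The estimate for compound 4 is 100000 nM, within 30000 nM to 300000 nM, which means an expected step of a number no higher from compound 3 to compound 4 (the limit leaves the size open).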

Compound 4, half-maximal cytotoxic concentration in the HEp-2 assay: > 100000 nM
Compound 4: only a limit was reported; the forecaster's own chance of this, stated with the estimate: 80%; the middle value sits exactly at the limit.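

In the HEp-2 assay compound 3 gives > 100000 nM, which is a limit of the assay. In the HEp-2 assay compound 4 gives > 100000 nM, which is also a limit of the assay. Among the compounds shown here, both are reported only as limits, so no step between them can be read. The compounds shown leave open what actual number any of the four would give in the HEp-2 assay. In a physicochemical assay for solubility, read by spectrophotometry, in phosphate buffer, at pH 6.5 (a lower number here means a less soluble compound, a higher number a more soluble compound), compound 3 gives 40 ug/mL and compound 4 gives 1 ug/mL. In the physicochemical assay this is a 40-fold lower number from compound 3 to compound 4 (1.60 log units; beyond the scatter).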